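Compound 4 and the limit of the series

This account rests on a few compounds, and the source may have more. Where it says the series, first, only, none or still open, it means among the compounds named here.

Compound 1 `COc1ccc(/C=C/[C@@](C)(/C=C/c2ccc(O)c(/C=C/C#N)c2)CCC=C(C)C)cc1` gives > 26000 nM in a functional assay on Raji cells (Homo sapiens) for cytotoxicity, with a stated time of 72 h (on this read-out higher numbers stand for an effect only at larger amounts of compound and lower numbers for an effect already at smaller amounts), as a limit. Compound 2 `COc1ccc(/C=C/[C@@](C)(/C=C/c2ccc(O)cc2)CCC=C(C)C)cc1` gives > 26000 nM as a limit too. Compound 3 `CC(C)=CCC[C@@](C)(/C=C/c1ccc(C)cc1)/C=C/c1ccc(O)cc1` stands at > 26000 nM as a limit as well. Going by the values given here, the series so far sits at the limit of > 26000 nM in this assay, at which 3 of the 3 values shown sit, without exception.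

Compound 4 `CC(C)=CCC[C@](C)(/C=C/c1ccc(O)cc1)/C=C/c1cccc(Cl)c1` brings the change 3-chlorophenyl in place of 4-methylphenyl on a double-bonded chain carbon bound to a double-bonded chain carbon with 3-chlorophenyl in place of 4-methylphenyl on a double-bonded chain carbon bound to a double-bonded chain carbon. Both a step that the two limits leave unreadable from compound 1 to compound 2 and a step that the two limits leave unreadable from compound 2 to compound 3 bear on it yet give no size to carry over, so no step beyond the scatter is expected in this assay for this change. The expected step is a number no higher from compound 3 to compound 4 (the limit leaves the size open) at this stage. Compound 4 is estimated at 26000 nM with an expected range from 10000 nM to 40000 nM and is expected to be a limit too.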

Compound 4, half-maximal effective concentration: > 26000 nM
Compound 4 gave a limit, no number (the forecaster's own chance of this, stated with the estimate: 75%); the middle value sits exactly at the limit.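

In this assay, no new step can be read for compound 4 against compound 2 or compound 3, since all values remain limits: the limit of > 26000 nM in this assay, at which 4 of the 4 values shown sit.

The compounds shown leave open which change, if any, would give a number rather than a limit.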